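Sulfonyl aryl swap on the shared core

The source may hold more compounds than are shown below. What is called first, only, known or untested is meant among the compounds shown, and "the series" means these compounds.

Compound 1 `COc1ccc(-c2cc(=O)c3c(OC)cc(OC)cc3n2S(=O)(=O)c2ccc(C)c([N+](=O)[O-])c2)cc1` and compound 2 `COc1ccc(-c2cc(=O)c3c(OC)cc(OC)cc3n2S(=O)(=O)c2cc(Cl)cc(Cl)c2O)cc1` share one core and differ only in the aryl on the sulfonyl sulfur. In an ADME assay on BJ cells (Homo sapiens) for antiproliferative activity, with a stated time of 72 h (a higher number here means that more compound is needed for the effect, a lower number that less compound is needed), compound 1 reaches only a limit, > 51700 nM. In this assay compound 2 likewise reaches only a limit, > 37900 nM. The step that the two limits leave unreadable from compound 1 to compound 2 cannot be read from two limits. Compound 3 `COc1ccc(-c2cc(=O)c3c(OC)cc(OC)cc3n2S(=O)(=O)c2ccc(Br)cc2)cc1` arises from compound 2 by 4-bromophenyl in place of 3,5-dichloro-2-hydroxyphenyl on a sulfonyl sulfur. No readable step bears on this change, so no size or direction beyond the scatter can be expected in this assay. Compound 3 is estimated at 40000 nM, range 5000 nM to 100000 nM, most probably again a limit. The expected step that the limit leaves unreadable from compound 2 to compound 3 is an estimate only.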

Compound 3, half-maximal effective concentration: > 86200 nM
Compound 3 was reported as a limit (the forecaster's own chance of this, stated with the estimate: 70%); middle value at least 2.1-fold (0.33 log units) from the limit.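

Among the compounds shown here, compound 1, compound 2 and compound 3 all stand only as limits in this assay, so no step among them can be read. Going by these compounds, whether the aryl on the sulfonyl sulfur changes the effective concentration at all remains open.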